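The compounds below may be only part of what the source reports. "The series", "measured", "known", "first", "only" and "open" are said of these compounds alone.

Measured compounds in this study:

Compound 1, `CC(C)(N)C(=O)N[C@H](COCc1ccccc1)c1nnnn1CCCCC#N`: 3120 nM
Compound 2, `CC(C)(N)C(=O)N[C@H](COCc1ccccc1)c1nnnn1CC#N`: 4170 nM
Compound 3, `CC(C)(N)C(=O)N[C@H](COCc1ccccc1)c1nnn(CCCCC#N)n1`: a limit only, > 5000 nM

All three were examined in an assay on isolated protein for displacement of a labelled ligand from growth hormone secretagogue receptor type 1 (Homo sapiens), with a stated time of 1 h; on this read-out lower numbers stand for stronger inhibition and higher numbers for weaker inhibition. Compound 1 and compound 2 share a core and differ in one place: cyano in place of 3-cyanopropyl on a saturated chain carbon bound to an aromatic nitrogen. In this assay that change gave a 1.3-fold higher number from compound 1 to compound 2 (0.13 log units; within the scatter), so the two compounds are not told apart by this measurement.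

Compound 3 carries the same atoms as compound 1, joined differently, and how the two cores differ is not broken down here. For compound 3 this assay returns only a limit of the assay and not a number, > 5000 nM. That reading sits at the limit of > 5000 nM in this assay, at which 1 of the 3 values shown sits.

Compound 4, `CC(C)(N)C(=O)N[C@H](COCc1ccccc1)c1nnn(CC#N)n1`, has not yet been measured in this assay. It stands to compound 3 as compound 2 stands to compound 1, and the change is the same one at the same place: cyano in place of 3-cyanopropyl on a saturated chain carbon bound to an aromatic nitrogen. Because the same change between compound 1 and compound 2 gave a 1.3-fold higher number from compound 1 to compound 2 (0.13 log units; within the scatter), the step from compound 3 to compound 4 is expected to be a step that the limit leaves unreadable from compound 3 to compound 4, a step within the usual scatter. Since compound 3 itself sits at a limit, compound 4 is expected to remain at or beyond that limit as well. Compound 4 is therefore estimated at about 8000 nM, most likely between 4000 nM and 20000 nM.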

Compound 4, inhibition constant: > 5000 nM
Compound 4: a limit, no number; the forecaster's own chance of this, stated with the estimate: 75%; the middle value is on the limit's open side.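

Like compound 3, compound 4 returns in this assay only a limit of the assay and not a number (> 5000 nM), and that reading now sits with the other one: (the limit of > 5000 nM in this assay, at which 2 of the 4 values shown sit). On the core of compound 1 the exchange of 3-cyanopropyl for cyano gave a 1.3-fold higher number from compound 1 to compound 2 (0.13 log units; within the scatter) and on the core of compound 3 the same exchange cannot be read, as both ends of that step are limits, so the data neither confirm nor refute that the change carries over from one core to the other. The two cyanomethyl compounds are joined by an at least 1.1-fold higher number from compound 2 to compound 4 (0.07 log units; that floor lies within the scatter) and, as that floor lies within the scatter, this comparison shows no measured separation between the two cores, though it does not exclude a larger one.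

The compounds shown leave open how far past the limit compound 3 and compound 4 lie, and whether the exchange has any real size on their core. They also leave open whether a carboxylic acid or an amine in place of the nitrile, or a chain longer than 3-cyanopropyl, in this assay would give either core a readable number.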